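From Isopropyl to Cyclopropyl on the Urea Nitrogen

This account rests on a few compounds, and the source may have more. Where it says the series, first, only, none or still open, it means among the compounds named here.

Going by the values given here, compound 2 `CC(C)NC(=O)NCc1ccccc1-c1ccc(CN2C(=O)[C@H](NC(=O)C(C)(C)N)CCc3ccccc32)cc1` stands at the higher of the two numbers so far recorded in a functional assay (Pituitary gland cell) with Rattus norvegicus as the target (on this read-out lower numbers stand for an effect already at smaller amounts and higher numbers for an effect only at larger amounts of compound), giving 270 nM. Among the compounds with values here, its only measured neighbour is compound 1 `CCNC(=O)NCc1ccccc1-c1ccc(CN2C(=O)[C@H](NC(=O)C(C)(C)N)CCc3ccccc32)cc1`, which in this assay gives 6 nM; the step between them, a 45-fold higher number from compound 1 to compound 2 (1.65 log units; beyond the scatter), is large and well beyond the scatter. Compound 3 `CC(C)(N)C(=O)N[C@@H]1CCc2ccccc2N(Cc2ccc(-c3ccccc3CNC(=O)NC3CC3)cc2)C1=O` has not yet been measured and differs from compound 2 in a single place: cyclopropyl in place of isopropyl on an amide-type nitrogen. Within the data shown here, the one measured step that bears on this change is the one from compound 1 to compound 2, where a methyl in place of hydrogen on the saturated chain carbon bound to the amide-type nitrogen cost a great deal. Compound 3 keeps the same heavy-atom count as the isopropyl but closes the group into a three-membered ring, a shape between the ethyl of compound 1 and the isopropyl of compound 2. Because a 45-fold higher number from compound 1 to compound 2 (1.65 log units; beyond the scatter) was so large, compound 3 is expected to move back toward the lower number, though not fully. The estimate for compound 3 is 40 nM, with a range from 8 nM to 200 nM. This corresponds to an expected step of a 6.8-fold lower number from compound 2 to compound 3 (0.83 log units; beyond the scatter).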

Compound 3, concentration for half-maximal effect: 45 nM
The estimate for compound 3 lay 1.1-fold (0.05 log units) below the measured number; the range from low to high includes it.
By their numbers in this assay, from the lowest: compound 1; then compound 3; then compound 2.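

In this assay the earlier pair had shown only that isopropyl on this amide-type nitrogen stood far from ethyl, and cyclopropyl, with the same count of heavy atoms as isopropyl, now gives a 6.0-fold lower number from compound 2 to compound 3 (0.78 log units; beyond the scatter) and so shows that the heavy-atom count alone does not set the number at this position. Closing the three carbons into a ring does not bring the number back to that of the ethyl compound, as the comparison with it gives a 7.5-fold higher number from compound 1 to compound 3 (0.88 log units; beyond the scatter) and leaves the cyclopropyl compound in the middle of the three. Nothing measured here accounts for either step, so the difference between the ring and the open group stays without an explanation.

The compounds shown leave open how a methyl, an unbranched propyl chain or a larger ring such as cyclobutyl would compare on the same nitrogen, and so whether ethyl is a true optimum or only the best of these three groups. They also leave open whether the same order of ethyl, cyclopropyl and isopropyl would hold on a different core.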